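Replacing the 3-hydroxy-4-methoxyphenyl group of compound 3

The compounds below may be only part of what the source reports. "The series", "measured", "known", "first", "only" and "open" are said of these compounds alone.

Measured in a functional assay on DU-145 cells (Homo sapiens) for inhibition, read by trypan blue exclusion, with a stated time of 96 h; on this read-out higher numbers stand for weaker inhibition of growth and lower numbers for stronger inhibition of growth:
compound 1 `Cc1cc(C)cc(/C=C(/SCc2ccc(F)cc2)C(=O)c2ccc(Br)cc2)c1` gives 10000 nM
compound 2 `CN(C)c1ccc(/C=C(/SCc2ccc(F)cc2)C(=O)c2ccc(Br)cc2)cc1` gives 50000 nM
compound 3 `COc1ccc(/C=C(/SCc2ccc(F)cc2)C(=O)c2ccc(Br)cc2)cc1O` gives 1000 nM

On this assay compound 3 gives the lowest number of the three, and both other compounds stand beyond the scatter from it. The next structure is compound 4 `O=C(/C(=C\c1ccc(O)cc1)SCc1ccc(F)cc1)c1ccc(Br)cc1` and the change is 4-hydroxyphenyl in place of 3-hydroxy-4-methoxyphenyl on a double-bonded chain carbon bound to a double-bonded chain carbon with 4-hydroxyphenyl in place of 3-hydroxy-4-methoxyphenyl on a double-bonded chain carbon bound to a double-bonded chain carbon.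

Among the compounds with values here, no measured step makes this exact change. The nearest evidence comes from exchanges at the same place: a 10-fold lower number from compound 1 to compound 3 (1.00 log units; beyond the scatter) is modest, a 50-fold lower number from compound 2 to compound 3 (1.70 log units; beyond the scatter) is large, and a 5.0-fold higher number from compound 1 to compound 2 (0.70 log units; beyond the scatter) is also modest. Within the data shown here, only three groups have been compared there, and the data do not separate the contributions of the hydroxy and methoxy parts of the group in compound 3. Since compound 3 alone carries this group and gives 1000 nM the likelier direction is upward, toward weaker inhibition of growth, and a modest size is expected. The expected change is a 4.0-fold higher number from compound 3 to compound 4 (0.60 log units; beyond the scatter) and a result within the scatter is not excluded. On this assay compound 4 is estimated at 4000 nM with an expected range from 800 nM to 20000 nM in this series.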

Compound 4, concentration for 50% growth inhibition: 10000 nM
The estimate for compound 4 lay 2.5-fold (0.40 log units) below the measured number, and the stated range covers the measured number.
By their numbers in this assay, from the lowest: compound 3; then compounds 1 and 4 (each within the scatter of the next); then compound 2.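

Within this assay, moving from the 3-hydroxy-4-methoxyphenyl group to the 4-hydroxyphenyl group gives the first direct reading of what the larger group contributes at this place (a 10-fold higher number from compound 3 to compound 4 (1.00 log units; beyond the scatter)), and a hydroxy group on the aromatic ring does not by itself retain the number of compound 3. The 4-hydroxyphenyl and 3,5-dimethylphenyl groups cannot be told apart on this read-out (no change at the digits printed from compound 1 to compound 4 (within the scatter)), so compound 3 now stands apart from two differently substituted rings rather than from a single comparison. Hydroxy in place of dimethylamino on an aromatic carbon also gives a clear step (a 5.0-fold lower number from compound 2 to compound 4 (0.70 log units; beyond the scatter)), which leaves compound 2 with the highest number of the series and beyond the scatter of compound 4.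

The compounds shown leave open whether the low number of compound 3 depends on the methoxy group, on the particular arrangement of hydroxy and methoxy, or on both, and how a ring bearing only methoxy, an amine or a carboxylic acid would behave at this place. Nothing in hand accounts for the sizes of these steps.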